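This account rests on a few compounds, and the source may have more. Where it says the series, first, only, none or still open, it means among the compounds named here.

Measured so far:
- compound 1, `C=C1[C@@H](OC(C)=O)C[C@@H]2[C@](C)(CO[Si](C)(C)C(C)(C)C)[C@H](OC(C)=O)CC[C@@]2(C)[C@@H]1C[C@@H](Nc1ccccc1)C1=CCOC1=O`: 4050 nM
- compound 2, `C=C1[C@@H](OC(C)=O)C[C@@H]2[C@](C)(COC=O)[C@H](OC(C)=O)CC[C@@]2(C)[C@@H]1C[C@@H](Nc1ccc(Br)cc1)C1=CCOC1=O`: 13200 nM
- compound 3, `C=C1[C@@H](OC(C)=O)C[C@@H]2[C@](C)(COC=O)[C@H](OC(C)=O)CC[C@@]2(C)[C@@H]1C[C@@H](Nc1ccc(C(=O)O)cc1)C1=CCOC1=O`: 37200 nM

In a functional assay on HT-29 cells (Homo sapiens) for cytotoxicity, read by sulforhodamine B assay (a higher number here means a weaker inhibitor, a lower number a stronger inhibitor), compound 3 gives 37200 nM, the highest of the three numbers; compound 2 gives 13200 nM and compound 1 gives 4050 nM, both lower by more than the scatter. Compound 4, `C=C1[C@@H](OC(C)=O)C[C@@H]2[C@](C)(COC=O)[C@H](OC(C)=O)CC[C@@]2(C)[C@@H]1C[C@@H](Nc1ccccc1)C1=CCOC1=O`, is not yet measured. It differs from compound 3 by hydrogen in place of carboxy on an aromatic carbon, so that the (4-carboxyphenyl)amino group becomes anilino.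

Among the measured compounds shown here, one measured step bears on this: a 2.8-fold higher number from compound 2 to compound 3 (0.45 log units; beyond the scatter), a modest rise when carboxy enters in place of bromo. Compound 1 also carries anilino and shows a lower number than compound 3, but it differs in a second place as well, so only the two values can be compared. Taking carboxy away is therefore expected to move the number down, by a modest step, back toward the range of compounds 1 and 2.

Compound 4 is estimated at 9000 nM in this assay, within 3500 nM to 22000 nM. This estimate means a 4.1-fold lower number from compound 3 to compound 4 (0.62 log units; beyond the scatter), expected to be beyond the scatter.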

Compound 4, half-maximal inhibitory concentration: 28800 nM
Beside the measured number, compound 4's estimate is 3.2-fold (0.51 log units) below it; the measured number lies above the stated range.
By their numbers in this assay, from the lowest: compound 1; then compound 2; then compounds 4 and 3 (each within the scatter of the next).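

In this assay the step of a 1.3-fold lower number from compound 3 to compound 4 (0.11 log units; within the scatter) leaves carboxy and hydrogen on this aromatic carbon indistinguishable, so the earlier rise from bromo to carboxy does not mark carboxy as a group that sets its compound apart from the plain anilino compound. Bromo is the group that separates from hydrogen here, with a 2.2-fold higher number from compound 2 to compound 4 (0.34 log units; beyond the scatter) as a modest step beyond the scatter. The change away from the aromatic ring, a group of 2 heavy atoms in place of a group of 7 heavy atoms on an oxygen on a saturated carbon, also counts, giving a 7.1-fold higher number from compound 1 to compound 4 (0.85 log units; beyond the scatter) as a step beyond the scatter.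

From the compounds shown here alone, whether methoxy, fluoro or an amine on the same aromatic carbon would fall with bromo or with hydrogen stays open, as does the effect of a free hydroxyl on that oxygen. Nothing available accounts for any of these steps.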